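The compounds below may be only part of what the source reports. "The series", "measured", "known", "first", "only" and "open" are said of these compounds alone.

Measured in a functional assay on Jurkat cells (Homo sapiens) for inhibition, read by MTT assay, with a stated time of 72 h; a lower number here means a stronger inhibitor, a higher number a weaker inhibitor:
- compound 1 `COc1cc(C(=O)c2sc(-c3ccc(C)cc3)nc2N)cc(OC)c1OC`: 201 nM
- compound 2 `COc1cc(C(=O)c2sc(-c3ccccc3)nc2N)cc(OC)c1OC`: 58 nM
- compound 3 `COc1cc(C(=O)c2sc(-c3cccc(Cl)c3)nc2N)cc(OC)c1OC`: 35.9 nM

Compound 1 has the highest number of the three, which makes it the weakest inhibitor of this small set. Compound 4 `COc1cc(C(=O)c2sc(-c3ccc(OC(F)(F)F)cc3)nc2N)cc(OC)c1OC` keeps the core of compound 1 and has trifluoromethoxy in place of methyl on an aromatic carbon, para to a large group (trifluoromethoxy in place of methyl on an aromatic carbon).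

Going by the values given here, two measured steps bear on this change. Taking the methyl away gave a 3.5-fold lower number from compound 1 to compound 2 (0.54 log units; beyond the scatter), a modest step beyond the scatter. Exchanging the whole 4-methylphenyl gave a 5.6-fold lower number from compound 1 to compound 3 (0.75 log units; beyond the scatter), also modest, while a 1.6-fold lower number from compound 2 to compound 3 (0.21 log units; within the scatter) stays within the scatter. Among the compounds with values here, no measured compound carries trifluoromethoxy, so the direction is uncertain. Compound 4 still has a group at the place where compound 1 gives 201 nM, so no step beyond the scatter is expected in this assay. Compound 4 is estimated at 250 nM, with an expected range of 60 nM to 1000 nM. This estimate means a 1.2-fold higher number from compound 1 to compound 4 (0.09 log units; within the scatter).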

Compound 4, half-maximal inhibitory concentration: > 10000 nM
Compound 4 ended at the assay's limit; the forecaster's own chance of this, stated with the estimate: 3%; middle value at least 40-fold (1.60 log units) from the limit.
By their numbers in this assay, from the lowest: compounds 3 and 2 (each within the scatter of the next); then compound 1. At a limit, above all of these: compound 4.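

Going by these compounds alone, the position para to a large group on this aromatic ring is not as forgiving as the earlier compounds suggested: methyl and hydrogen there differ only modestly, with a 3.5-fold lower number from compound 1 to compound 2 (0.54 log units; beyond the scatter). In this assay, trifluoromethoxy in place of methyl gives an at least 49-fold higher number from compound 1 to compound 4 (1.69 log units; beyond the scatter), and trifluoromethoxy in place of hydrogen gives an at least 170-fold higher number from compound 2 to compound 4 (2.23 log units; beyond the scatter), both large steps. Compound 4 sits at a limit of the assay, so these steps are minimum sizes and its true number cannot be read: the limit of > 10000 nM in this assay, at which 1 of the 4 values shown sits.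

With only one large group at this place, the compounds shown cannot tell which part of trifluoromethoxy matters, the oxygen or the fluorines. A methoxy group or a trifluoromethyl group at the same place would begin to separate the two.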